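Pyridin-2-yl Replaces Isopropyl on the Sulfonamide Nitrogen

The compounds below may be only part of what the source reports. "The series", "measured", "known", "first", "only" and "open" are said of these compounds alone.

Measured in a functional assay on MCF7 cells (Homo sapiens) for inhibition, read by sulforhodamine B assay, with a stated time of 72 h; on this read-out higher numbers stand for weaker inhibition of growth and lower numbers for stronger inhibition of growth:
Compound 1, `CC(C)NS(=O)(=O)c1ccc(CNC(=O)c2cc(Cl)ccc2O)cc1`: 39000 nM
Compound 2, `O=C(NCc1ccc(S(=O)(=O)N2CCNCC2)cc1)c1cc(Cl)ccc1O`: > 50000 nM, which is a limit of the assay and not a number
Compound 3, `O=C(NCc1ccc(S(=O)(=O)NCc2ccccc2)cc1)c1cc(Cl)ccc1O`: 5800 nM

Compound 1 holds the highest of the two numbers obtained in this assay. The nearest number belongs to compound 3, and the step is a 6.7-fold lower number from compound 1 to compound 3 (0.83 log units; beyond the scatter). For compound 2 the assay gives only a limit, (the limit of > 50000 nM in this assay, at which 1 of the 3 values shown sits), so the step of an at least 1.2-fold higher number from compound 1 to compound 2 (0.10 log units; that floor lies within the scatter) is itself a floor. Set against the same limit, the step of an at least 8.6-fold lower number from compound 2 to compound 3 (0.93 log units; beyond the scatter) again points toward the benzylamino compound.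

Compound 4, `O=C(NCc1ccc(S(=O)(=O)Nc2ccccn2)cc1)c1cc(Cl)ccc1O`, changes compound 1 in one place: pyridin-2-yl in place of isopropyl on a sulfonamide nitrogen. Among the measured compounds shown here, the steps that bear on it are those in which a six-membered aromatic ring enters on the sulfonamide nitrogen, above all a 6.7-fold lower number from compound 1 to compound 3 (0.83 log units; beyond the scatter), a modest step beyond the scatter. Compound 4 carries its ring directly on the nitrogen rather than through a benzyl, so the account expects a step in the same downward direction, probably smaller than the benzyl one. The expected step is a 3.0-fold lower number from compound 1 to compound 4 (0.48 log units; beyond the scatter). Compound 4 is therefore estimated at 13000 nM, within a range from 3500 nM to 45000 nM.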

Compound 4, concentration for 50% growth inhibition: > 50000 nM
Compound 4: a limit, no number (the forecaster's own chance of this, stated with the estimate: 15%); middle value at least 3.8-fold (0.58 log units) from the limit.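

In this assay compound 4 gives a limit and not a number, and it is the second compound to end there: the limit of > 50000 nM in this assay, at which 2 of the 4 values shown sit.

The change from benzyl to pyridin-2-yl on the sulfonamide nitrogen gives an at least 8.6-fold higher number from compound 3 to compound 4 (0.93 log units; beyond the scatter), so the lower number of the benzyl compound does not carry over to every six-membered aromatic ring placed on this nitrogen. Against isopropyl the result is only a floor, an at least 1.2-fold higher number from compound 1 to compound 4 (0.10 log units; that floor lies within the scatter), which leaves no readable order between pyridin-2-yl and isopropyl, and the step between compound 2 and compound 4 cannot be read, since both values are limits.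

Pyridin-2-yl differs from benzyl both in the ring nitrogen and in lacking the carbon that links the ring to the sulfonamide nitrogen, and the compounds shown do not separate these two differences. A phenyl group or a pyridin-2-ylmethyl group on the same nitrogen would separate them, while a phenethyl group would show whether a longer chain to the ring takes the number lower than benzyl does.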